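Side chain change from compound 3 to compound 4

This account rests on a few compounds, and the source may have more. Where it says the series, first, only, none or still open, it means among the compounds named here.

Measured in a functional assay on NCI-H1299 cells (Homo sapiens), read by flow cytometry; a higher number here means that more compound is needed for the effect, a lower number that less compound is needed (each value a limit and not a number):
- Compound 1 `N#Cc1ncc2nc1OCC/C=C\COc1ccc(CCOC3CCCCO3)cc1NC(=O)N2` gives > 10000 nM (a limit)
- Compound 2 `N#Cc1ncc2nc1OCC/C=C\COc1ccc(CCO)cc1NC(=O)N2` gives > 10000 nM (a limit)
- Compound 3 `N#Cc1ncc2nc1OCC/C=C\COc1ccc(CCCO)cc1NC(=O)N2` gives > 10000 nM (a limit)

Compound 3 has no numeric value in this assay, only a limit (> 10000 nM). It shares this position with the others (the limit of > 10000 nM in this assay, at which 3 of the 3 values shown sit). Compound 4 `N#Cc1ncc2nc1OCC/C=C\COc1ccc(OCCO)cc1NC(=O)N2` carries 2-hydroxyethoxy in place of 3-hydroxypropyl on an aromatic carbon. Among the compounds with values here, three measured steps touch this side chain (a step that the two limits leave unreadable from compound 1 to compound 2; a step that the two limits leave unreadable from compound 1 to compound 3; a step that the two limits leave unreadable from compound 2 to compound 3). None of them has a readable size, so they give no direction for the new step. The closest comparison is the change of the chain between compound 2 and compound 3, and it too ends at a limit. No step beyond the scatter is therefore expected in this assay, and a further limit is the likeliest report. The expected change is small (a number no higher from compound 3 to compound 4 (the limit leaves the size open)). The estimate for compound 4 is 10000 nM (expected range 4000 nM to 25000 nM).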

Compound 4, half-maximal effective concentration: > 10000 nM
Compound 4: only a limit was reported; the forecaster's own chance of this, stated with the estimate: 75%; the middle value lies on the limit itself.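

In this assay, within the data shown here, compound 4 gives > 10000 nM, a limit and not a number, so no step to compound 4 from compound 1, compound 2 or compound 3 can be read. The compounds shown leave open whether any of these side chains gives a numeric value in this assay, and how 2-hydroxyethoxy compares with 3-hydroxypropyl there.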